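The source may hold more compounds than are shown below. What is called first, only, known or untested is meant among the compounds shown, and "the series" means these compounds.

So far, two compounds sharing one core have numbers in a functional assay on MDA-MB-435 cells (Homo sapiens) for cytotoxicity, read by MTT assay, with a stated time of 72 h; on this read-out lower numbers stand for stronger inhibition and higher numbers for weaker inhibition. Compound 1 (`Nc1ccc(Nc2c(C(=O)NCc3ccc(F)cc3)nc(Br)c3cccnc23)cc1`) gives 7000 nM and compound 2 (`N[C@H]1CC[C@H](Nc2c(C(=O)NCc3ccc(F)cc3)nc(Br)c3cccnc23)CC1`) gives 6000 nM, so compound 2 stands level with compound 1, and the data do not separate them. Compound 3 (`O=C(NCc1ccc(F)cc1)c1nc(Br)c2cccnc2c1N1CCNCC1`) keeps the same core and changes a single group: piperazin-1-yl in place of (4-aminocyclohexyl)amino on an aromatic carbon. The swap puts piperazin-1-yl in place of (4-aminocyclohexyl)amino on an aromatic carbon, para to a bromo group. A six-membered non-aromatic ring of carbon only thus gives way to one with hetero atoms.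

Among the compounds with values here, only one measured step bears on this change, because it alters the group at that same place: a 1.2-fold lower number from compound 1 to compound 2 (0.07 log units; within the scatter). It is a single step and it stayed within the scatter. Within the data shown here, no measured compound yet carries piperazin-1-yl, so the evidence is thin and the range must stay wide. No shift beyond the scatter is expected in this assay, in either direction. The expected step is no change at the digits printed from compound 2 to compound 3 (within the scatter). For compound 3 the estimated value is 6000 nM, with an expected range from 2000 nM to 20000 nM.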

Compound 3, half-maximal inhibitory concentration: 8000 nM
Compound 3: the middle estimate sits 1.3-fold (0.12 log units) below what was measured; measured number inside the range.
By their numbers in this assay, from the lowest: compounds 2, 1 and 3 (each within the scatter of the next).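

Piperazin-1-yl, a six-membered non-aromatic ring with 2 hetero atoms, now joins the series at this aromatic carbon, and in this assay the comparison with the (4-aminocyclohexyl)amino group gives a 1.3-fold higher number from compound 2 to compound 3 (0.12 log units; within the scatter), while the comparison with the (4-aminophenyl)amino group gives a 1.1-fold higher number from compound 1 to compound 3 (0.06 log units; within the scatter); both steps lie within the scatter. Compound 3 also gives up the 2 defined stereocentres of compound 2 and has 1 hydrogen-bond donor in the entering group instead of 2, yet this assay does not separate the compounds, so three different rings at this place now read alike, which two compounds alone could not show. Nothing available explains why the numbers stay together.

Still open, going by these compounds, is whether a different kind of group at this aromatic carbon, such as a carboxylic acid or an open-chain amine with a longer chain, would move the number beyond the scatter. Also open, on these data alone, is what a chloro group in place of the bromo group would do, and whether the flat reading at this carbon would hold with that change.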